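From a Methylphenyl to a Trifluorophenyl Group

The source may report more compounds than this note shows. Statements on the series, on what has been measured and on what is new or still open speak of the compounds shown alone.

Compound 1: `Cc1cccc(CN2Cc3c(NC(=O)c4ccccc4)n[nH]c3C2(C)C)c1` — 1100 nM
Compound 2: `CC1(C)c2[nH]nc(NC(=O)c3ccccc3)c2CN1Cc1ccc(F)c(F)c1` — 680 nM
Compound 3: `Cc1ccc(CN2Cc3c(NC(=O)c4ccccc4)n[nH]c3C2(C)C)cc1F` — 940 nM

All three compounds were tested in an assay on Sf21 cells for inhibition of high affinity nerve growth factor receptor (Homo sapiens), read by HTRF, with a stated time of 30 min, in the presence of a further agent that is not named here (on this read-out lower numbers stand for stronger inhibition and higher numbers for weaker inhibition), and share one core, differing only in the aromatic group attached on a saturated chain carbon bound to an amine nitrogen in a ring. Compound 1 stands with the highest of the three numbers, but both of its neighbours lie within the usual scatter of it: a 1.2-fold lower number from compound 1 to compound 3 (0.07 log units; within the scatter) and a 1.6-fold lower number from compound 1 to compound 2 (0.21 log units; within the scatter). Compound 2 and compound 3 likewise lie within the scatter of each other, a 1.4-fold higher number from compound 2 to compound 3 (0.14 log units; within the scatter).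

Compound 4, `CC1(C)c2[nH]nc(NC(=O)c3ccccc3)c2CN1Cc1cc(F)c(F)c(F)c1`, has not yet been measured in this assay. It differs from compound 1 thus: 3,4,5-trifluorophenyl in place of 3-methylphenyl on a saturated chain carbon bound to an amine nitrogen in a ring. The two measured steps that bear on it are those from compound 1 to the fluorine-bearing compound 2 and compound 3, each of which moved the number only slightly toward the lower side and stayed inside the scatter. Nothing larger is expected here. A small shift toward a lower number, a 1.5-fold lower number from compound 1 to compound 4 (0.17 log units; within the scatter), is the estimate for compound 4. Compound 4 is therefore expected to give about 750 nM, with a range from 380 nM to 1500 nM.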

Compound 4, half-maximal inhibitory concentration: 6960 nM
Compound 4: middle estimate off by 9.3-fold (0.97 log units), on the low side; measured number above the stated range.
By their numbers in this assay, from the lowest: compounds 2, 3 and 1 (each within the scatter of the next); then compound 4.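

In this assay, the place on a saturated chain carbon bound to an amine nitrogen in a ring had seemed to accept a change of aromatic group with little effect, but 3,4,5-trifluorophenyl shows that it does not accept every such group (a 6.3-fold higher number from compound 1 to compound 4 (0.80 log units; beyond the scatter); a 7.4-fold higher number from compound 3 to compound 4 (0.87 log units; beyond the scatter)). Going by these compounds alone, the clearest comparison is with 3,4-difluorophenyl, where putting fluoro in place of hydrogen on an aromatic carbon is the only change and gives the largest step in the set (a 10-fold higher number from compound 2 to compound 4 (1.01 log units; beyond the scatter)), so fluoro at one aromatic carbon can matter far more here than the swaps among the earlier groups, which all stayed within the scatter. No measurement at hand explains this jump.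

The compounds shown leave open whether the jump belongs to fluoro specifically or would also appear with another group on that same aromatic carbon, such as chloro, methoxy or an amine. They also leave open whether the shared core would respond in the same way if the benzoyl amide on it were replaced by an acetyl amide.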